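A Methyl Added to a Well-Tolerated Core

The source may hold more compounds than are shown below. What is called first, only, known or untested is meant among the compounds shown, and "the series" means these compounds.

Compound 1 `O=c1cc(Cc2c(F)cccc2F)nc(SCc2c(F)cccc2F)[nH]1` gives, in an ADME assay on MT4 cells (Homo sapiens) for cytotoxicity, read by MTT assay (a higher number here means that more compound is tolerated, a lower number that less compound is tolerated), only a limit: > 66000 nM.
Compound 2 `O=C(CSc1nc(Cc2c(F)cccc2F)cc(=O)[nH]1)c1ccccc1` gives in this assay only a limit: > 67000 nM.
Compound 3 `O=C(CSc1nc(Cc2c(F)cccc2F)cc(=O)[nH]1)c1ccc(Cl)cc1` gives in this assay only a limit: > 61000 nM.

All three values shown are limits rather than numbers, so compound 2 cannot be placed above or below its neighbours; it simply sits at the limit described by the limit of > 67000 nM in this assay, at which 1 of the 3 values shown sits. The three steps between the measured compounds, a step that the two limits leave unreadable from compound 1 to compound 2, a step that the two limits leave unreadable from compound 1 to compound 3 and a step that the two limits leave unreadable from compound 2 to compound 3, are all left unreadable by the pair of limits on either side, so none of them tells how much any of these changes matters.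

Compound 4 `Cc1c(Cc2c(F)cccc2F)nc(SCC(=O)c2ccccc2)[nH]c1=O` differs from compound 2 by methyl in place of hydrogen on an aromatic carbon. The nearest measured parallel is the step from compound 2 to compound 3, also a small group replacing hydrogen on an aromatic carbon, and there both compounds stayed at their limits. Going by the values given here, with no step readable in any direction, the expectation is that compound 4 too will remain at the limit, with no step beyond the scatter. Compound 4 is therefore estimated at 70000 nM, within 30000 nM to 200000 nM. The expected step is a step that the limit leaves unreadable from compound 2 to compound 4.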

Compound 4, half-maximal cytotoxic concentration: 65000 nM
Estimate against measurement, compound 4: 1.1-fold (0.03 log units) above, and the stated range covers the measured number.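

Going by these compounds alone, compound 4 is the first compound to give an actual number rather than a limit: in this assay compound 4 gives 65000 nM. Placing a methyl on this aromatic carbon of the shared core, ortho to a 2,6-difluorobenzyl group, gives an at least 1.0-fold lower number from compound 2 to compound 4 (0.01 log units; that floor lies within the scatter), so all that can be said is that the data show no change beyond the scatter, and the true size of the step could be larger than this floor. The reading is one-sided, since the value for compound 2 is a limit and not a number: the limit of > 67000 nM in this assay, at which 1 of the 4 values shown sits.

As far as these compounds go, what remains open is whether this position would tolerate something bigger or of a different kind, such as an ethyl group, a longer chain or an amine, without the number falling beyond the scatter. From the compounds shown here alone, it is also open whether the same methyl would behave in the same way on compound 1 or compound 3, whose values are limits as well.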